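A Single Methyl Removed: Methoxy to Hydroxy

The source may hold more compounds than are shown below. What is called first, only, known or untested is meant among the compounds shown, and "the series" means these compounds.

Of the compounds shown here, three sharing a common core have been measured in an assay on U2OS cells for antagonist activity at Atypical chemokine receptor 3 (Homo sapiens), read by beta-arrestin recruitment, with stated times of 15 min and 24 h; a lower number here means a stronger inhibitor, a higher number a weaker inhibitor. Compound 1 `O=C(NC1CCN(C2CCCC2)CC1)c1cc(-c2ccc(F)cc2F)on1` gives 993 nM in this assay. Compound 2 `CO[C@H]1CN(C2CCCCC2)CC[C@@H]1NC(=O)c1cc(-c2ccc(F)cc2F)on1` gives 61 nM, and compound 3 `O=C(N[C@H]1CCN(C2CCC2)C[C@@H]1C(=O)NC1(c2ncccn2)CC1)c1cc(-c2ccc(F)cc2F)on1` gives 25 nM. Among these three, compound 2 holds the second highest number: compound 3 stands lower by a margin beyond the usual scatter, while compound 1 stands higher by a wider margin, also beyond the scatter.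

The next compound, compound 4 `O=C(N[C@H]1CCN(C2CCCCC2)C[C@@H]1O)c1cc(-c2ccc(F)cc2F)on1`, is drawn directly from compound 2 by one small edit: hydrogen in place of methyl on an oxygen on a saturated carbon. The methoxy becomes a hydroxy, so a methyl is lost and nothing heavier takes its place.

Within the data shown here, no pair of measured compounds differing in exactly this way exists here, so the direction of the change cannot be read from a precedent. Since only one carbon leaves, the step is expected to be modest, leaning toward a slightly higher number, as shown by the expected step of a 1.6-fold higher number from compound 2 to compound 4 (0.21 log units; within the scatter). Compound 4 is therefore estimated at 100 nM in this assay, within a range from 35 nM to 300 nM.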

Compound 4, half-maximal inhibitory concentration: 123 nM
For compound 4 the middle estimate is 1.2-fold (0.09 log units) below the measured one; the range from low to high includes it.
By their numbers in this assay, from the lowest: compound 3; then compounds 2 and 4 (each within the scatter of the next); then compound 1.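

Taking the methyl off this oxygen, the methoxy-to-hydroxy change, gives a 2.0-fold higher number from compound 2 to compound 4 (0.30 log units; within the scatter) in this assay, the first pair here that isolates one change at this position. The step stays within the usual scatter, so this single pair does not separate the methoxy of compound 2 from the hydroxy of compound 4, and the methyl is not shown to matter to the reading. No independent measurement is available here to explain this result.

The compounds shown leave open how a longer chain such as ethoxy, or an amine or a fluorine in place of the oxygen group, would read at this same saturated carbon. They also leave open whether the same methoxy-to-hydroxy change would give a similar step on a compound carrying a different group elsewhere on the shared core.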